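Swapping chloro for fluoro: a free fraction estimate

A few compounds are considered here, and "the series" means these few. Any claim that something is new, unique, unknown or untested is made for them only; others in the source may bear on it.

Measured so far in an ADME assay on a cell-free system (plasma, Mus musculus); on this read-out higher numbers stand for a larger free fraction and lower numbers for a smaller free fraction:
- compound 1 `CC(C)c1ccc(S(C)(=O)=O)cc1C#Cc1cc(Cl)ccc1OCC(=O)O`: 0.013
- compound 2 `CS(=O)(=O)c1ccc(Cl)c(C#Cc2cc(Cl)ccc2OCC(=O)O)c1`: 0.025

Among the compounds with values here, compound 2 stands at 0.025, within the scatter of the only other number. Compound 3 `CS(=O)(=O)c1ccc(F)c(C#Cc2cc(Cl)ccc2OCC(=O)O)c1` makes one change to it: fluoro in place of chloro on an aromatic carbon, para to a methylsulfonyl group (fluoro in place of chloro on an aromatic carbon). Within the data shown here, one measured step bears on this, a swap at the same place: a 1.9-fold higher number from compound 1 to compound 2 (0.28 log units; within the scatter). That step is a different swap and stayed within the scatter, so the expectation is no shift beyond the scatter in this assay, with an estimated 1.2-fold higher number from compound 2 to compound 3 (0.08 log units; within the scatter). For compound 3 the estimated value is 0.03, with an expected range from 0.015 to 0.06.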

Compound 3, unbound fraction: 0.054
Beside the measured number, compound 3's estimate is 1.8-fold (0.26 log units) below it, within the range that was stated.
By their numbers in this assay, from the lowest: compounds 1 and 2 (each within the scatter of the next); then compound 3.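

In this assay this carbon now yields a change beyond the scatter, since fluoro in place of chloro gives a 2.2-fold higher number from compound 2 to compound 3 (0.33 log units; beyond the scatter) and a modest step is enough to show it. Fluoro in place of isopropyl gives a 4.2-fold higher number from compound 1 to compound 3 (0.62 log units; beyond the scatter) and so the group at this one position can measurably shift the free fraction, which the earlier step within the scatter could not show. No supporting data explain this shift.

From the compounds shown here alone, whether a nitrile or a methoxy group at this carbon would give a larger free fraction remains open, as does whether the fluoro gain would hold with another group replacing the methylsulfonyl group.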